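A few compounds are considered here, and "the series" means these few. Any claim that something is new, unique, unknown or untested is made for them only; others in the source may bear on it.

Working notes on the series in a functional assay on CHO cells with adenosine receptor A1 (Homo sapiens) as the target, read by cAMP accumulation and immunoassay, with a stated time of 6 min, tested at 0.1 uM; on this read-out lower numbers stand for a stronger effect and higher numbers for a weaker effect at the one concentration tested.

Compound 1, `Nc1scc(CN2CCN(c3cc(Cl)cc(Cl)c3)CC2)c1C(=O)c1ccc(Cl)cc1`, gives -22%. Compound 2, `COc1ccc(N2CCN(Cc3csc(N)c3C(=O)c3ccc(Cl)cc3)CC2)cc1`, gives 0%. Compound 3, `Nc1scc(CN2CCN(c3cccc(F)c3)CC2)c1C(=O)c1ccc(Cl)cc1`, gives -37% and stands lowest of the three numbers; compound 1 is nearest, compound 2 furthest, and the steps of a number 15 percentage points lower from compound 1 to compound 3 (beyond the scatter) and a number 37 percentage points lower from compound 2 to compound 3 (beyond the scatter) are both beyond the scatter. Among the measured compounds, the chlorine-bearing aryl of compound 1 and the fluorine-bearing aryl of compound 3 sit on the low side, while the methoxy-bearing aryl of compound 2 sits high, as a number 22 percentage points higher from compound 1 to compound 2 (beyond the scatter) shows.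

Compound 4, `Nc1scc(CN2CCN(c3cc(Cl)ccc3Cl)CC2)c1C(=O)c1ccc(Cl)cc1`, is the next member. Change: 2,5-dichlorophenyl in place of 3-fluorophenyl on an amine nitrogen in a ring. Within the data shown here, the steps that bear on it are a number 15 percentage points lower from compound 1 to compound 3 (beyond the scatter), where a dichlorophenyl became a fluorophenyl, and a number 22 percentage points higher from compound 1 to compound 2 (beyond the scatter). Among the measured compounds shown here, compound 4 carries two chlorines like compound 1, arranged as 2,5-dichlorophenyl rather than 3,5-dichlorophenyl; no measured pair isolates that rearrangement. The expectation is therefore a value for compound 4 near compound 1 or between compound 1 and compound 3, that is a modest step upward, a number 12 percentage points higher from compound 3 to compound 4 (beyond the scatter), of uncertain size because a number 15 percentage points lower from compound 1 to compound 3 (beyond the scatter) is itself modest. Compound 4 is estimated at -25%, with a range of -45% to -5%.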

Compound 4, a percentage reported as activity, at one concentration (the size of the read-out at that concentration, not a potency): -6.2%
Beside the measured number, compound 4's estimate is 18.8 percentage points below it; the range from low to high includes it.
By their numbers in this assay, from the lowest: compound 3; then compound 1; then compounds 4 and 2 (each within the scatter of the next).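

With the same two chlorines on the aryl and only their arrangement changed, a number 15.8 percentage points higher from compound 1 to compound 4 (beyond the scatter) shows that in this assay the read-out at this amine nitrogen depends on where the chlorines sit on the phenyl ring, not only on their presence. Replacing the 3-fluorophenyl with the 2,5-dichlorophenyl gives a number 30.8 percentage points higher from compound 3 to compound 4 (beyond the scatter), while replacing the 4-methoxyphenyl gives a number 6.2 percentage points lower from compound 2 to compound 4 (within the scatter), so the earlier picture of chlorine-bearing aryls on the low side holds for the 3,5-dichlorophenyl but not for the 2,5-dichlorophenyl, which reads level with the 4-methoxyphenyl. No measurement available here bears on the reason for these differences.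

It remains open which of the two chlorines of the 2,5-dichlorophenyl accounts for the shift, and a phenyl with a single chlorine, an unsubstituted phenyl or a pyridyl ring on the same ring nitrogen would help to separate their contributions. The series is also read at one concentration only, so how these differences at the aryl translate into potency remains unresolved.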